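This account rests on a few compounds, and the source may have more. Where it says the series, first, only, none or still open, it means among the compounds named here.

Compound 1 `CN(C)c1ccc(C(=O)N[C@@H](CCCCCC(=O)NO)C(=O)NCc2ccccc2)cc1` in a functional assay on MM96L cells (Homo sapiens) for antiproliferative activity (on this read-out higher numbers stand for weaker inhibition and lower numbers for stronger inhibition), gives 1600 nM, the highest number among the three compounds measured. Among the measured compounds shown here, compound 2 `CN(C)c1ccc(C(=O)NC(CCCCCC(=O)NO)C(=O)NCc2ccccc2)cc1` differs from compound 1 only in a stereocentre drawn without configuration; in this assay compound 2 gives 130 nM, a step of a 12-fold lower number from compound 1 to compound 2 (1.09 log units; beyond the scatter); the only evidence bearing on that step is the fact that one of compounds 1 and 2 is drawn with a defined configuration and the other without, at the place where they differ. Compound 3 `O=C(CCCCC[C@H](NC(=O)c1cc2c(O)cccc2[nH]1)C(=O)NCc1ccccc1)NO`, with 4-hydroxy-1H-indol-2-yl in place of 4-(dimethylamino)phenyl on a carbonyl carbon, gives 330 nM, a step of a 4.8-fold lower number from compound 1 to compound 3 (0.69 log units; beyond the scatter).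

Compound 4 `CN(C)c1ccc(C(=O)N[C@@H](CCCCCC(=O)NO)C(=O)NCc2ccccn2)cc1` keeps the stereocentre and the 4-(dimethylamino)phenyl group of compound 1 and changes only the benzylcarbamoyl end: pyridin-2-yl in place of phenyl on a saturated chain carbon bound to an amide-type nitrogen. For the measured compounds named here, neither measured step touches this part of the shared core, so no step of either size transfers directly. The two measured changes both lowered the number, but nothing shows how the benzyl position responds. He therefore expects for compound 4 a step of no change at the digits printed from compound 1 to compound 4 (within the scatter), within the scatter in this assay. His estimate for compound 4 is 1600 nM, with a range from 500 nM to 5000 nM.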

Compound 4, half-maximal inhibitory concentration: 3600 nM
The estimate for compound 4 lay 2.3-fold (0.35 log units) below the measured number, within the range that was stated.
By their numbers in this assay, from the lowest: compound 2; then compound 3; then compound 1; then compound 4.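

The benzylcarbamoyl end of the shared core is not silent in this assay: pyridin-2-yl in place of phenyl on a saturated chain carbon bound to an amide-type nitrogen gives a 2.3-fold higher number from compound 1 to compound 4 (0.35 log units; beyond the scatter) and is the only change shown that raises the number. The heavy-atom count stays the same, and the swap of one ring carbon for nitrogen, which brings in one hydrogen-bond acceptor, is enough for a modest step beyond the scatter. Nothing given here bears on why the number moved at this position.

As far as these compounds go, whether pyridin-3-yl or pyridin-4-yl would give a similar step remains open, as does the effect of an amine or a carboxylic acid on the phenyl ring. Also open, from the compounds shown here alone, is whether this swap would give a similar step in compound 2 or compound 3.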